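A few compounds are considered here, and "the series" means these few. Any claim that something is new, unique, unknown or untested is made for them only; others in the source may bear on it.

Compound 1 `CCOc1ccc(C(=O)CSc2nc3ccccc3[nH]2)cc1` belongs to a small set of compounds that share one core. In a functional assay on HT-29 cells (Homo sapiens) for inhibition, read by WST assay, with a stated time of 48 h (on this read-out higher numbers stand for weaker inhibition and lower numbers for stronger inhibition), compound 1 gives only a limit, > 100000 nM, and this is the limit of > 100000 nM in this assay, at which 1 of the 2 values shown sits. Its relative compound 2 `COc1ccccc1C(=O)CSc1nc2ccccc2[nH]1` gives 36100 nM in this assay. Compound 3 `O=C(CSc1nc2ccccc2[nH]1)c1ccc([N+](=O)[O-])cc1` is the next one to be tested. It differs from compound 1 by a single change, (nitro in place of ethoxy on an aromatic carbon), nitro in place of ethoxy on an aromatic carbon. Among the compounds with values here, no measured step covers such a change. A move toward stronger inhibition is expected, an at least 2.5-fold lower number from compound 1 to compound 3 (0.39 log units; beyond the scatter), rather than none beyond the scatter. Compound 3 is estimated at 40000 nM, with a range from 8000 nM to 150000 nM.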

Compound 3, half-maximal inhibitory concentration: 57000 nM
Compound 3: the middle estimate sits 1.4-fold (0.15 log units) below what was measured; measured number inside the range.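

Within the data shown here, with nitro in place of ethoxy on an aromatic carbon, para to a large group, this assay yields a measured number at this position for the first time, and the change gives an at least 1.7-fold lower number from compound 1 to compound 3 (0.24 log units; that floor lies within the scatter). The true step could be larger, but this floor alone does not establish a change beyond the scatter. Compound 1 remains a limit, not a number: the limit of > 100000 nM in this assay, at which 1 of the 3 values shown sits.

On these data alone, whether an amine or a carboxylic acid at this same position would give a lower number than compound 3 remains open.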